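A few compounds are considered here, and "the series" means these few. Any claim that something is new, unique, unknown or untested is made for them only; others in the source may bear on it.

Measured compounds:
Compound 1 `Cc1nc(C(NC(=O)C(=O)Nc2ccc(F)cc2)C2CCCCN2)sc1CCO` gives in an ADME assay on TZM-b1 cells (Homo sapiens) for cytotoxicity, read by XTT assay, with a stated time of 3 days (a higher number here means that more compound is tolerated, a lower number that less compound is tolerated), only a limit, > 88000 nM.
Compound 2 `Cc1nc(C(NC(=O)C(=O)Nc2ccc(Cl)cc2)C2CCCCN2)sc1CO` gives in this assay only a limit, > 22000 nM.
Compound 3 `Cc1nc(C(NC(=O)C(=O)Nc2ccc(Cl)cc2)C2CCCN2)sc1CO` gives in this assay 12400 nM.

Among the compounds with values here, compound 2 thus stands at a limit rather than at a number in this assay, one of two limits among the three values, and the only measured step that touches it, an at least 1.7-fold lower number from compound 2 to compound 3 (0.24 log units; that floor lies within the scatter), concerns the saturated ring and not the anilide end.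

Compound 4 `Cc1nc(C(NC(=O)C(=O)NC2CCCCCC2)C2CCCCN2)sc1CO` is not yet measured. It differs from compound 2 in one place: cycloheptyl in place of 4-chlorophenyl on an amide-type nitrogen. Within the data shown here, no measured step alters the group on this amide-type nitrogen, so nothing among the three compounds speaks for or against a change at this position in this assay. Since compound 2 itself sits at a limit, and compound 1 at a higher limit, the limit of > 22000 nM in this assay, at which 1 of the 3 values shown sits, and the limit of > 88000 nM in this assay, at which 1 of the 3 values shown sits, show that such limits are common in this set.

Compound 4 is therefore expected to show no step beyond the scatter, a step that the limit leaves unreadable from compound 2 to compound 4, and is estimated at 30000 nM, between 10000 nM and 90000 nM.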

Compound 4, half-maximal cytotoxic concentration: > 90000 nM
Compound 4 ended at the assay's limit; the forecaster's own chance of this, stated with the estimate: 60%; at least 3.0-fold (0.47 log units) between middle value and limit.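

Compound 2 and compound 4 both stand at limits in this assay, so the step between them, cycloheptyl in place of 4-chlorophenyl on an amide-type nitrogen, cannot be read. The compounds shown leave open whether this change shifts the number in this assay at all, and in which direction.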